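Swapping iodo for fluoro on a thiosemicarbazone

The compounds below may be only part of what the source reports. "The series", "measured", "known", "first", "only" and "open" are said of these compounds alone.

Measured compounds:
Compound 1 `CC(=NNC(=S)Nc1cccc(I)c1)c1ccccn1` — 84 nM
Compound 2 `C/C(=N\NC(=S)Nc1cccc(I)c1)c1ccccn1` — 84 nM
Compound 3 `C/C(=N/NC(=S)Nc1cccc(I)c1)c1ccccn1` — 84 nM

Three drawings of the same molecule open the series. In a functional assay on U-87MG ATCC cells (Homo sapiens) for cytotoxicity, read by MTT assay, with a stated time of 48 h (a lower number here means a stronger inhibitor, a higher number a weaker inhibitor), compound 1 gives 84 nM, compound 2 gives 84 nM and compound 3 gives 84 nM. The steps of no change at the digits printed from compound 1 to compound 2 (within the scatter), no change at the digits printed from compound 1 to compound 3 (within the scatter) and no change at the digits printed from compound 2 to compound 3 (within the scatter) all stay within the scatter, which fits (the fact that one of compounds 1 and 2 is drawn with a defined configuration and the other without, at the place where they differ), the fact that one of compounds 1 and 3 is drawn with a defined configuration and the other without, at the place where they differ and the fact that compounds 2 and 3 differ only in the configuration as drawn: the three entries differ only in how the double bond is drawn. For the measured compounds named here, compound 2 therefore stands level with compounds 1 and 3, with no compound closer or further than another.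

Going by the values given here, compound 4 `C/C(=N\NC(=S)Nc1cccc(F)c1)c1ccccn1` is the first real change of structure. The difference from compound 2 is fluoro in place of iodo on an aromatic carbon. Among the compounds with values here, none of the measured steps bears on this change, since each of them concerns only the drawing of a configuration and none touches the halogen. The expectation for compound 4 in this assay thus rests on compound 2 alone, and its size cannot be read from any earlier step. A wide range is the honest outcome; the estimated step of a 3.0-fold higher number from compound 2 to compound 4 (0.47 log units; beyond the scatter) leans toward weaker inhibition. Compound 4 is estimated at 250 nM, between 50 nM and 1200 nM.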

Compound 4, half-maximal inhibitory concentration: 18 nM
Compound 4: middle estimate off by 14-fold (1.14 log units), on the high side, outside the stated range (below it).
By their numbers in this assay, from the lowest: compound 4; then compounds 1, 2 and 3 (each within the scatter of the next).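

In this assay, for the compounds shown here, the halogen on the aromatic carbon is the first place where a change of structure moves the number (a 4.7-fold lower number from compound 2 to compound 4 (0.67 log units; beyond the scatter)), whereas the earlier steps all stayed within the scatter and touched only how the double bond is drawn. This place on the six-membered aromatic ring, meta to a large group, therefore responds to the identity of the halogen, with fluoro giving the lower number and iodo the higher, although one heavy atom simply replaces another and no ring, hydrogen-bond donor, hydrogen-bond acceptor or net charge enters or leaves. The facts on record concern only the drawing of the double bond and none of them speaks to this exchange of halogens.

As far as these compounds go, with only iodo and fluoro at this place, two points fix no trend, and it remains open whether chloro or bromo would fall with compound 4, with compound 2 or at some level of their own. Also open, from the compounds shown here alone, is how a group other than a halogen, such as methoxy or an amine, would read at the same aromatic carbon.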